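Aryl replacement on compound 1: expectation for compound 4

The compounds below may be only part of what the source reports. "The series", "measured", "known", "first", "only" and "open" are said of these compounds alone.

Measured so far in an assay for inhibition of histone deacetylase 4 (Homo sapiens); a higher number here means a weaker inhibitor, a lower number a stronger inhibitor:
compound 1, `O=C(c1ccc(-c2nc(-c3ccccn3)no2)s1)C(F)(F)F`: 90 nM
compound 2, `O=C(c1ccc(-c2nc(-c3cccc(C(F)(F)F)c3)no2)s1)C(F)(F)F`: 320 nM
compound 3, `O=C(c1ccc(-c2nc(-c3cccs3)no2)s1)C(F)(F)F`: 95 nM

Compound 1 has the lowest number of the three; compound 3 sits within the scatter of it, compound 2 beyond it. Compound 4, `Cc1cccc(-c2noc(-c3ccc(C(=O)C(F)(F)F)s3)n2)c1`, differs from compound 1 by 3-methylphenyl in place of pyridin-2-yl on an aromatic carbon. Going by the values given here, the one measured step of the same kind, a 1.1-fold higher number from compound 1 to compound 3 (0.02 log units; within the scatter), is an aryl-for-aryl swap that changed nothing beyond the scatter. The other precedent is compound 2, which carries a substituted carbon-only ring in the same place and gives 320 nM where compound 1 gives 90 nM. A modest rise in this assay is therefore expected, smaller than that seen for compound 2. Compound 4 is estimated at 180 nM, with a range of 80 nM to 450 nM, an expected step of a 2.0-fold higher number from compound 1 to compound 4 (0.30 log units; within the scatter).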

Compound 4, half-maximal inhibitory concentration: 280 nM
The estimate for compound 4 lay 1.6-fold (0.19 log units) below the measured number; low and high end bracket the measured number.
By their numbers in this assay, from the lowest: compounds 1 and 3 (each within the scatter of the next); then compounds 4 and 2 (each within the scatter of the next).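

In this assay not every aryl swap at this position is silent: 3-methylphenyl gives a 3.1-fold higher number from compound 1 to compound 4 (0.49 log units; beyond the scatter) and also a 2.9-fold higher number from compound 3 to compound 4 (0.47 log units; beyond the scatter) as modest steps. Methyl in place of trifluoromethyl gives a 1.1-fold lower number from compound 2 to compound 4 (0.06 log units; within the scatter) on the carbon-only ring, so this assay does not separate these two substituents. Nothing measured here accounts for these steps.

Unsubstituted phenyl would show whether the rise goes with the carbon-only ring or with its substituent. From the compounds shown here alone, an amine or a carboxylic acid on that ring remains open as well.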